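Removing a Thiazole Methyl from a Weak Antiproliferative Compound

The source may hold more compounds than are shown below. What is called first, only, known or untested is meant among the compounds shown, and "the series" means these compounds.

Measured compounds:
- compound 1 `C#CCSc1nc(Sc2nccs2)c(C#N)c(-c2ccc(C)cc2)n1`: 4300 nM
- compound 2 `C#CCSc1nc(Sc2nc(C)c(C)s2)c(C#N)c(-c2cc(OC)c(OC)c(OC)c2)n1`: > 20000 nM

Of the compounds shown here, two have been tested in a functional assay on KYSE-70 cells for antiproliferative activity against KYSE-70 cell line (Homo sapiens), read by MTT assay, with a stated time of 72 h; a higher number here means a weaker inhibitor, a lower number a stronger inhibitor. Compound 1 `C#CCSc1nc(Sc2nccs2)c(C#N)c(-c2ccc(C)cc2)n1` gives 4300 nM in this assay. Compound 2 `C#CCSc1nc(Sc2nc(C)c(C)s2)c(C#N)c(-c2cc(OC)c(OC)c(OC)c2)n1` reaches only the limit of this assay, > 20000 nM, so no number is known for it, only that it lies beyond what the assay can report; this is the situation described by the limit of > 20000 nM in this assay, at which 1 of the 2 values shown sits. Compound 1 and compound 2 differ in more than one place, so their two values show only that one is measurable and the other is not.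

The next compound, compound 3 `C#CCSc1nc(Sc2nc(C)cs2)c(C#N)c(-c2cc(OC)c(OC)c(OC)c2)n1`, has not been measured. It differs from compound 2 as follows: hydrogen in place of methyl on an aromatic carbon. The change is small: one carbon on the five-membered ring is replaced by hydrogen, with nothing else altered. For the measured compounds named here, no measured pair shows what such a change does here, so the expectation rests on compound 2 alone.

Compound 3 is therefore expected to stay close to where compound 2 sits, and the step of a number no higher from compound 2 to compound 3 (the limit leaves the size open) is estimated to be no larger than the scatter. The estimate for compound 3 in this assay is 20000 nM, within a range from 6000 nM to 60000 nM, with a real chance that only a limit is reported again.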

Compound 3, half-maximal inhibitory concentration: > 20000 nM
Compound 3: no number, only a limit (the forecaster's own chance of this, stated with the estimate: 55%); the middle value lies on the limit itself.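

In this assay, for the compounds shown here, compound 2 and compound 3 both give only a limit and not a number, so no step between them can be read: the limit of > 20000 nM in this assay, at which 2 of the 3 values shown sit.

From the compounds shown here alone, whether going from the 4,5-dimethyl-1,3-thiazol-2-yl group to the 4-methyl-1,3-thiazol-2-yl group changes activity at all therefore stays open.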